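This account rests on a few compounds, and the source may have more. Where it says the series, first, only, none or still open, it means among the compounds named here.

Compound 1, `C/N=C(/S)[C@@]1(c2cccnc2)CCCC[C@@H]1CCOC(=O)c1ccccc1`, is the reference point of this small series. In a functional assay (aorta) with Rattus norvegicus as the target (on this read-out higher numbers stand for weaker inhibition and lower numbers for stronger inhibition), compound 1 gives 30 nM. Compound 2, `C/N=C(/S)[C@@]1(c2cccnc2)CCCC[C@@H]1CCOC(=O)c1ccc(F)cc1`, carries one change relative to compound 1, (fluoro in place of hydrogen on an aromatic carbon), and in this assay compound 2 gives 100 nM, a step of a 3.3-fold higher number from compound 1 to compound 2 (0.52 log units; beyond the scatter). Compound 3, `C/N=C(/S)[C@@]1(c2cccnc2)CCCC[C@@H]1CCNC(=O)c1ccccc1`, differs from compound 1 in its core, (benzamido in place of benzoyloxy on a saturated chain carbon, two bonds along the chain from a saturated ring carbon); in this assay compound 3 gives 300 nM, which is a 10-fold higher number from compound 1 to compound 3 (1.00 log units; beyond the scatter) and the highest number of the three measured compounds. Compound 4, `C/N=C(/S)[C@@]1(c2cccnc2)CCCC[C@@H]1CCNC(=O)c1ccc(F)cc1`, has not yet been measured. It stands to compound 3 as compound 2 stands to compound 1: fluoro in place of hydrogen on an aromatic carbon, at a place described in the same words for both pairs, so this is the same change made on a different core. Within the data shown here, the only guide to its effect is the step from compound 1 to compound 2. Compound 4 is therefore expected to show a step of about a 3.0-fold higher number from compound 3 to compound 4 (0.48 log units; beyond the scatter) from compound 3, because the same change gave a 3.3-fold higher number from compound 1 to compound 2 (0.52 log units; beyond the scatter). On that basis compound 4 is estimated at 900 nM, with a likely range from 300 nM to 2700 nM.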

Compound 4, concentration for 90% inhibition: 500 nM
The estimate for compound 4 lay 1.8-fold (0.26 log units) above the measured number, within the range that was stated.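

In this assay, the fluoro change on the core of compound 3 gives a 1.7-fold higher number from compound 3 to compound 4 (0.22 log units; within the scatter), so on this core its effect cannot be told apart from the ordinary scatter of repeated measurements. Set beside the same change on the core of compound 1, the two steps do not differ by more than such measurements would allow: the same change on two cores in this assay, a 3.3-fold higher number (0.52 log units; beyond the scatter) from compound 1 to compound 2 and a 1.7-fold higher number (0.22 log units; within the scatter) from compound 3 to compound 4, 2.0-fold (0.30 log units) apart, within the scatter of two such steps. Among these compounds, this shows that the size of the step carried across the two cores without a detectable difference, but it does not show that the effect is identical, as one step lies beyond the scatter and the other within it, and each core offers only a single pair.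

The compounds shown leave open whether other groups at that place, such as chloro, methoxy or an amine, would carry across these two cores in the same way. They also leave open whether the fluoro change would hold on a core with a longer chain or with a sulfonamide in place of the ester or amide.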